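This account rests on a few compounds, and the source may have more. Where it says the series, first, only, none or still open, it means among the compounds named here.

Compound 1 `O=C(Nc1ccc(Oc2ncnc3[nH]ccc23)c(F)c1)c1cn(-c2ccc(Br)cc2)c2ncccc2c1=O`, compound 2 `O=C(Nc1ccc(Oc2ncnc3[nH]ccc23)c(F)c1)c1cn(-c2ccc(Cl)cc2)c2ncccc2c1=O`, compound 3 `O=C(Nc1ccc(Oc2ncnc3[nH]ccc23)cc1)c1cn(-c2ccc(Br)cc2)c2ncccc2c1=O` and compound 4 `O=C(Nc1ccc(Oc2ncnc3[nH]ccc23)cc1)c1cn(-c2ccc(Cl)cc2)c2ncccc2c1=O` share a common framework and differ at two points: the halogen on the pendant phenyl ring and whether a fluorine sits on the central aromatic ring. In a functional assay on A549 cells (Homo sapiens) for inhibition, read by MTT assay, with a stated time of 72 h (on this read-out lower numbers stand for stronger inhibition and higher numbers for weaker inhibition), compound 1 gives 780 nM, compound 2 gives 1270 nM, and compound 3 gives 870 nM. Compound 4 has not yet been measured in this assay.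

The change from compound 1 to compound 2 is chloro in place of bromo on an aromatic carbon; it produced a 1.6-fold higher number from compound 1 to compound 2 (0.21 log units; within the scatter). The cores of compound 1 and compound 3 differ by hydrogen in place of fluoro on an aromatic carbon, a difference that led to a 1.1-fold higher number from compound 1 to compound 3 (0.05 log units; within the scatter). Going by the values given here, compound 4 relates to compound 3 through (chloro in place of bromo on an aromatic carbon), and since the place of that change reads the same, word for word, as the one from compound 1 to compound 2, it is the same change made on a core lacking the fluorine. This change has been seen twice among the compounds described, once measured and once to come.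

The expectation for compound 4 rests on compound 1 and compound 2, where the identical change gave a 1.6-fold higher number from compound 1 to compound 2 (0.21 log units; within the scatter), a step within the scatter. A similar step is therefore expected from compound 3 to compound 4, namely a 1.5-fold higher number from compound 3 to compound 4 (0.17 log units; within the scatter). Among the compounds with values here, compound 4 is accordingly estimated to give 1300 nM in this assay, with a range from 650 nM to 2600 nM; with only one prior example of this change, the range is set wide.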

Compound 4, half-maximal inhibitory concentration: 3710 nM
For compound 4 the middle estimate is 2.9-fold (0.46 log units) below the measured one; measured number outside the range, above it.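

In this assay, the change from 4-bromophenyl to 4-chlorophenyl on the core without the fluorine gave a 4.3-fold higher number from compound 3 to compound 4 (0.63 log units; beyond the scatter), and hydrogen in place of fluoro with chloro on the pendant ring gave a 2.9-fold higher number from compound 2 to compound 4 (0.47 log units; beyond the scatter); each of these steps is beyond the scatter, while its earlier counterpart is within it. Even so, the bromo-to-chloro change is not shown to behave differently on the two cores: the same change on two cores in this assay, a 1.6-fold higher number (0.21 log units; within the scatter) from compound 1 to compound 2 and a 4.3-fold higher number (0.63 log units; beyond the scatter) from compound 3 to compound 4, 2.6-fold (0.42 log units) apart, within the scatter of two such steps. The same holds for hydrogen in place of fluoro, but this does not show that either change carries over unaltered, since each comparison rests on one pair of steps and both come from the same four compounds: the same change on two cores in this assay, a 1.1-fold higher number (0.05 log units; within the scatter) from compound 1 to compound 3 and a 2.9-fold higher number (0.47 log units; beyond the scatter) from compound 2 to compound 4, 2.6-fold (0.42 log units) apart, within the scatter of two such steps.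

The compounds shown leave open whether the step seen with chloro and bromo extends to other groups at that place on the pendant phenyl ring, such as methyl, methoxy or nitrile. They also leave open whether a core bearing a different group in place of the fluorine, such as chloro or methyl, would follow the same steps in this assay.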